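Swapping the benzyl for an aroyl group at the piperidine nitrogen

The compounds below may be only part of what the source reports. "The series", "measured", "known", "first", "only" and "open" are said of these compounds alone.

Compound 1 `COc1ccc2nccc(C3CN(C4CCN(Cc5cc6ccccc6n5C)CC4)C(=O)O3)c2c1`: 3160 nM
Compound 2 `COc1ccc2nccc(C3CN(C4CCN(CC5CCCCC5)CC4)C(=O)O3)c2c1`: 7940 nM
Compound 3 `COc1ccc2nccc(C3CN(C4CCN(Cc5cccc(Cl)c5)CC4)C(=O)O3)c2c1`: 6310 nM

Three compounds share a core and differ only in the group carried on a saturated chain carbon bound to an amine nitrogen in a ring. In an in vitro functional assay on RBL cells for antagonist activity at C-C chemokine receptor type 8 (Homo sapiens), read by FLIPR and calcium flux (a lower number here means a stronger inhibitor, a higher number a weaker inhibitor), compound 1 gives 3160 nM, compound 2 gives 7940 nM and compound 3 gives 6310 nM. Compound 3 holds the second highest of the three numbers; its nearest neighbour is compound 2, and the gap between them is within the scatter, as is its gap to compound 1. Of the measured steps, a 2.5-fold higher number from compound 1 to compound 2 (0.40 log units; beyond the scatter) is the only one beyond the scatter, while a 2.0-fold higher number from compound 1 to compound 3 (0.30 log units; within the scatter) and a 1.3-fold lower number from compound 2 to compound 3 (0.10 log units; within the scatter) stay within it.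

Compound 4 `COc1ccc2nccc(C3CN(C4CCN(C(=O)c5ccc(Cl)c(Cl)c5)CC4)C(=O)O3)c2c1` is not yet measured. The change is (3,4-dichlorophenyl)carbonyl in place of 3-chlorobenzyl on an amine nitrogen in a ring. For the measured compounds named here, none of the measured steps replaces the saturated chain carbon itself by a carbonyl, so the three steps bear on it only indirectly, through the varied aryl and alkyl groups, all of which moved the number by modest amounts at most. Compound 4 is therefore expected to land close to compound 3, with a 1.0-fold lower number from compound 3 to compound 4 (0.00 log units; within the scatter) as the estimated step and wide uncertainty. The estimate for compound 4 is 6300 nM, expected between 2000 nM and 20000 nM.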

Compound 4, half-maximal inhibitory concentration: 6310 nM
Estimate against measurement, compound 4: 1.0-fold (0.00 log units) below; the range from low to high includes it.
By their numbers in this assay, from the lowest: compounds 1, 3, 4 and 2 (each within the scatter of the next, the first and the last beyond it).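

In this assay, for the compounds shown here, (3,4-dichlorophenyl)carbonyl in place of 3-chlorobenzyl on the amine nitrogen in a ring gives no change at the digits printed from compound 3 to compound 4 (within the scatter), which shows that a carbonyl can stand on this nitrogen, where the earlier compounds all carry a saturated chain carbon, without a change this assay can resolve. The comparisons with the other two compounds agree, with a 1.3-fold lower number from compound 2 to compound 4 (0.10 log units; within the scatter) and a 2.0-fold higher number from compound 1 to compound 4 (0.30 log units; within the scatter), so compound 4 lies within the scatter of all three earlier compounds, even though compound 1 and compound 2 lie beyond it from each other. No measured information is available here to account for this result.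

This one change replaces the chain carbon with a carbonyl and also adds a chlorine, so the compounds shown cannot tell whether each change is silent alone or whether the two offset each other; a (3-chlorophenyl)carbonyl group and a 3,4-dichlorobenzyl group would separate them. Also open, going by these compounds, is whether the (1-methyl-1H-indol-2-yl) or cyclohexyl group behaves the same way on a carbonyl, and whether a sulfonyl group could stand in the carbonyl's place on this nitrogen.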